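Swapping fluoro for pyrrolidin-1-yl in compound 2

A few compounds are considered here, and "the series" means these few. Any claim that something is new, unique, unknown or untested is made for them only; others in the source may bear on it.

Measured values in a functional assay on HCT-116 cells (Homo sapiens) for antiproliferative activity, read by MTT assay, with a stated time of 24 h; a lower number here means a stronger inhibitor, a higher number a weaker inhibitor
Compound 1 `COc1cc(OC)c(OC)cc1/C=C/C(=O)c1ccc(OC)c2c1OC(C)(C)C=C2` gives > 10000 nM
Compound 2 `COc1ccc(C(=O)/C=C/c2ccc(F)cc2)c2c1C=CC(C)(C)O2` gives > 10000 nM
Compound 3 `COc1ccc(C(=O)/C=C/c2ccc(N(c3ccccc3)c3ccccc3)cc2)c2c1C=CC(C)(C)O2` gives > 10000 nM

Each of these entries is a limit of the assay and not a number. Compound 2 sits at the limit of > 10000 nM in this assay, at which 3 of the 3 values shown sit, and so offers no number to start from.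

Compound 4 `COc1ccc(C(=O)/C=C/c2ccc(N3CCCC3)cc2)c2c1C=CC(C)(C)O2` differs from compound 2 in one place: pyrrolidin-1-yl in place of fluoro on an aromatic carbon. Pyrrolidin-1-yl stands in place of fluoro on an aromatic carbon, para to a large group. For the measured compounds named here, no step between measured compounds gives a guide to its size. In this assay no change beyond the scatter is expected, in either direction, and the expected change is a number no higher from compound 2 to compound 4 (the limit leaves the size open). That expectation rests on (the limit of > 10000 nM in this assay, at which 3 of the 3 values shown sit), which includes compound 2. For compound 4 the estimated half-maximal inhibitory concentration is 10000 nM, with an expected range from 3000 nM to 30000 nM.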

Compound 4, half-maximal inhibitory concentration: 8590 nM
Beside the measured number, compound 4's estimate is 1.2-fold (0.07 log units) above it, within the range that was stated.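

Of the compounds shown, only compound 4 gives a number rather than a limit in this assay, so pyrrolidin-1-yl at this position brings the value into the readable range. The swap gives an at least 1.1-fold lower number from compound 2 to compound 4 (0.06 log units; that floor lies within the scatter). Compound 2 is only a limit, so this step is a floor and its true size stays open: the limit of > 10000 nM in this assay, at which 3 of the 4 values shown sit.

Going by these compounds, whether a smaller amine such as dimethylamino, or a six-membered ring such as piperidine or morpholine, would give a lower number here remains open. It is also unclear how much the ring itself contributes.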